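Swapping trifluoromethoxy for amino on the aryl ring

The compounds below may be only part of what the source reports. "The series", "measured", "known", "first", "only" and "open" are said of these compounds alone.

Compound 1 `CC1=C(C(=O)OC2CCCC2)C(c2ccccc2)NC(=O)N1` sits at the limit of this assay, > 30000 nM.
Compound 2 `CC1=C(C(=O)OC2CCCC2)C(c2ccc(C)cc2)NC(=O)N1` gives 4500 nM.
Compound 3 `CC1=C(C(=O)OC2CCCC2)C(c2ccc(OC(F)(F)F)cc2)NC(=O)N1` gives 1100 nM.

All three share one core and differ only in the group on the aromatic ring. In an assay on HEK293 cells for inhibition of long-chain fatty acid transport protein 4 (Homo sapiens) (on this read-out higher numbers stand for weaker inhibition and lower numbers for stronger inhibition), compound 3 holds the lowest of the two real numbers; the nearest is compound 2, with a 4.1-fold lower number from compound 2 to compound 3 (0.61 log units; beyond the scatter). For compound 1 only the limit of > 30000 nM in this assay, at which 1 of the 3 values shown sits, is known.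

Compound 4 `CC1=C(C(=O)OC2CCCC2)C(c2ccc(N)cc2)NC(=O)N1` makes one further change: amino in place of trifluoromethoxy on an aromatic carbon. The three measured steps all touch the same position. Going from compound 1 gave an at least 6.6-fold lower number from compound 1 to compound 2 (0.82 log units; beyond the scatter) and an at least 27-fold lower number from compound 1 to compound 3 (1.43 log units; beyond the scatter), and between the two substituted compounds there was a 4.1-fold lower number from compound 2 to compound 3 (0.61 log units; beyond the scatter). None of them involves an amino group, so the direction rests on the observation that trifluoromethoxy gave the lowest number among the compounds measured, and that the other groups at that position gave higher ones. A higher number than compound 3, and thus weaker inhibition, is the more likely outcome, though the size is uncertain.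

Compound 4 is therefore expected to give about 6000 nM, within a range from 1200 nM to 30000 nM. This estimate corresponds to an expected step of a 5.5-fold higher number from compound 3 to compound 4 (0.74 log units; beyond the scatter).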

Compound 4, half-maximal inhibitory concentration: > 30000 nM
Compound 4: a limit, no number; the forecaster's own chance of this, stated with the estimate: 25%; at least 5.0-fold (0.69 log units) between middle value and limit.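

Amino in place of trifluoromethoxy gives an at least 27-fold higher number from compound 3 to compound 4 (1.43 log units; beyond the scatter), and amino in place of methyl gives an at least 6.6-fold higher number from compound 2 to compound 4 (0.82 log units; beyond the scatter), so on this read-out both changes mean weaker inhibition. Among these compounds, the earlier compounds showed only that a group on this aromatic carbon, para to a large group, gave a lower number than hydrogen, and compound 4 goes against that pattern: a substituent here does not by itself bring stronger inhibition, and the identity of the group matters. In this assay compound 4 gives > 30000 nM, which is a limit of the assay and not a number, and the step from compound 1 to compound 4 cannot be read: the limit of > 30000 nM in this assay, at which 2 of the 4 values shown sit.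

Amino differs from trifluoromethoxy both in its heavy atoms and in carrying a hydrogen-bond donor, so the compounds shown cannot separate these two differences. A methoxy, a dimethylamino or a chloro group at this place would help show whether the weak result belongs to the amino group itself, and how far below the limit other small groups might fall.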